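Chloro in place of methoxy at the same aromatic carbon

The compounds below may be only part of what the source reports. "The series", "measured", "known", "first", "only" and "open" are said of these compounds alone.

Measured compounds:
compound 1, `N#Cc1ccc(Cc2cnc(CCc3ccc(-c4ccccc4C(=O)O)cc3)[nH]2)cc1`; in an in vitro functional assay on cells for agonist activity at Bombesin receptor subtype-3 (Mus musculus), read by luminescence and calcium flux (a higher number here means that more compound is needed for the effect, a lower number that less compound is needed), compound 1 gives 723 nM
compound 2, `COc1ccc(Cc2cnc(CCc3ccc(-c4ccccc4C(=O)O)cc3)[nH]2)cc1`; in this assay compound 2 gives 513 nM

Compound 2 and compound 1 stand within the scatter of each other, as the step of a 1.4-fold lower number from compound 1 to compound 2 (0.15 log units; within the scatter) shows. Compound 3, `O=C(O)c1ccccc1-c1ccc(CCc2ncc(Cc3ccc(Cl)cc3)[nH]2)cc1`, differs from compound 2 by chloro in place of methoxy on an aromatic carbon. Within the data shown here, the only step known at this carbon, from cyano to methoxy, stayed within the scatter; no measured step introduces a chloro group. Compound 3 is therefore expected to show a step of a 1.0-fold lower number from compound 2 to compound 3 (0.01 log units; within the scatter) that stays within the scatter. The estimate for compound 3 in this assay is 500 nM, between 230 nM and 1100 nM.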

Compound 3, half-maximal effective concentration: 102 nM
The estimate for compound 3 lay 4.9-fold (0.69 log units) above the measured number; measured number below the stated range.
By their numbers in this assay, from the lowest: compound 3; then compounds 2 and 1 (each within the scatter of the next).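

In this assay this carbon proved sensitive to its substituent after all: chloro gives a step beyond the scatter against methoxy (a 5.0-fold lower number from compound 2 to compound 3 (0.70 log units; beyond the scatter)) and against cyano (a 7.1-fold lower number from compound 1 to compound 3 (0.85 log units; beyond the scatter)), whereas cyano and methoxy had stayed within the scatter of each other. Of the three groups, only the 4-chlorobenzyl compound stands apart. Nothing available bears on why this is so. As far as these compounds go, whether the lower number is particular to chloro or also extends to fluoro, bromo or methyl remains open. So does whether chloro would give the same step at another carbon of this ring.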